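A few compounds are considered here, and "the series" means these few. Any claim that something is new, unique, unknown or untested is made for them only; others in the source may bear on it.

Measured so far in a physicochemical assay for solubility; on this read-out lower numbers stand for lower solubility and higher numbers for higher solubility:

- compound 1 `CC(=O)c1ccc(O)c(C(=O)Nc2ccc([N+](=O)[O-])cc2Cl)c1`: > 49 ug/mL
- compound 2 `NS(=O)(=O)c1ccc(NC(=O)c2cc(Cl)ccc2O)cc1`: > 48 ug/mL
- compound 3 `O=C(Nc1ccccc1C(F)(F)F)c1cc(Cl)ccc1O`: > 47 ug/mL

All three entries are limits of the assay and not exact numbers, so no order can be drawn among these compounds. Compound 2 stands at > 48 ug/mL, which is a limit, and the other two compounds shown give limits as well. On these data alone, its exact solubility therefore remains unknown.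

The next compound is compound 4 `Cc1ccc(NC(=O)c2cc(Cl)ccc2O)cc1`, in which methyl takes the place of sulfamoyl on an aromatic carbon, para to a large group: methyl in place of sulfamoyl on an aromatic carbon. For the measured compounds named here, no two measured compounds differ in one place only, so this assay offers no direct measure of what this exchange does.

The nearest guide is indirect. Compound 3 carries no sulfamoyl and reads > 47 ug/mL, also a limit, so a large fall is not expected for compound 4. A small downward step, or none that stands clear of the usual scatter, is the expectation, and the estimated change is an at least 1.3-fold lower number from compound 2 to compound 4 (0.13 log units; that floor lies within the scatter). For compound 4 the estimated solubility is 35 ug/mL, with an expected range from 12 ug/mL to 50 ug/mL.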

Compound 4, solubility: < 1 ug/mL
Compound 4: only a limit was reported (the forecaster's own chance of this, stated with the estimate: 60%); middle value at least 35-fold (1.54 log units) from the limit.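

In this assay, the aromatic carbon that bears sulfamoyl in compound 2 turns out to matter a great deal, as exchanging that group for methyl gives an at least 48-fold lower number from compound 2 to compound 4 (1.68 log units; beyond the scatter). This is the first pair shown that differs in one place only, so it gives the first direct reading of this position, and it shows that one group on an otherwise shared core can separate two compounds by far more than the usual scatter. The step is only a floor and its true size remains unknown, because both of its ends are limits and the lower end is this one: the limit of < 1 ug/mL in this assay, at which 1 of the 4 values shown sits.

A single pair cannot tell whether the fall comes from losing sulfamoyl or from gaining methyl, and a compound with plain hydrogen on that aromatic carbon would help to separate the two. On these data alone, it also remains open whether other groups in the same place, such as an amine, a carboxylic acid or a longer chain, would sit near compound 2 or near compound 4 on this read-out.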